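Aryl variation on the oxygen on a saturated carbon

This account rests on a few compounds, and the source may have more. Where it says the series, first, only, none or still open, it means among the compounds named here.

Measured compounds:
- compound 1, `CC(C)[C@H](NC(=O)COc1cccc2ccccc12)C(=O)N[C@@H](CC(=O)O)C(=O)COc1cccc(C(F)(F)F)c1`: 16600 nM
- compound 2, `CC(C)[C@H](NC(=O)COc1cccc2ccccc12)C(=O)N[C@@H](CC(=O)O)C(=O)COc1cc(F)ccc1F`: 19700 nM

Both measured compounds share the same core and differ only in the aryl group on an oxygen on a saturated carbon. In a functional assay with Homo sapiens as the target (a lower number here means a stronger inhibitor, a higher number a weaker inhibitor), compound 1 gives 16600 nM, and compound 2 gives 19700 nM. Compound 2 and compound 1 stand at the same level within the scatter; the step of a 1.2-fold higher number from compound 1 to compound 2 (0.07 log units; within the scatter) is within the scatter, so no ordering between them can be claimed.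

Compound 3, `CC(C)[C@H](NC(=O)COc1cccc2ccccc12)C(=O)N[C@@H](CC(=O)O)C(=O)COc1c(F)c(F)cc(F)c1F`, is not yet measured. The change from compound 2 to compound 3 is 2,3,5,6-tetrafluorophenyl in place of 2,5-difluorophenyl on an oxygen on a saturated carbon. For the measured compounds named here, the only measured step that touches this position is a 1.2-fold higher number from compound 1 to compound 2 (0.07 log units; within the scatter), where exchanging one aryl group for another at the same place moved the number within the scatter. On that basis no step beyond the scatter is expected in this assay for compound 3, in either direction, and the estimated step is a 1.1-fold lower number from compound 2 to compound 3 (0.04 log units; within the scatter). Compound 3 is therefore expected at about 18000 nM, with a range from 6000 nM to 55000 nM.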

Compound 3, half-maximal inhibitory concentration: 6250 nM
Compound 3: the middle estimate sits 2.9-fold (0.46 log units) above what was measured; the range from low to high includes it.
By their numbers in this assay, from the lowest: compound 3; then compounds 1 and 2 (each within the scatter of the next).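

In this assay the aryl group on the oxygen on a saturated carbon can move the number beyond the scatter, which the earlier exchange at this place did not show: the new group gives a 3.2-fold lower number from compound 2 to compound 3 (0.50 log units; beyond the scatter) and also a 2.7-fold lower number from compound 1 to compound 3 (0.42 log units; beyond the scatter) against the other aryl group, both steps modest. The 2,3,5,6-tetrafluorophenyl group therefore stands apart from both the 2,5-difluorophenyl and the 3-(trifluoromethyl)phenyl groups, which remain level with each other within the scatter, and compound 3 at 6250 nM is the strongest inhibitor of the three on the shared core. Nothing on hand gives a reason for this step.

Open is whether the lower number needs the full 2,3,5,6-tetrafluorophenyl pattern, since the compounds shown include neither an unsubstituted phenyl nor a pentafluorophenyl group at this place for comparison. Also open, from the compounds shown here alone, is whether an aryl ring carrying an amine or a carboxylic acid, or a saturated alkyl chain in place of the aryl group, would keep the number of compound 3 or take it lower still.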